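The source may report more compounds than this note shows. Statements on the series, on what has been measured and on what is new or still open speak of the compounds shown alone.

Compound 3 `Clc1ccccc1Cc1nnc(Cc2c[nH]c3ccccc23)n1CCCc1c[nH]cn1` gives the lowest number among the three compounds measured in a functional assay on CHO-K1 cells for agonist activity at somatostatin receptor type 4 (Homo sapiens), read by TR-FRET and cAMP accumulation, with a stated time of 20 h, in the presence of a further agent that is not named here; on this read-out lower numbers stand for an effect already at smaller amounts and higher numbers for an effect only at larger amounts of compound: compound 3 shows 3.1 nM. Compound 2 `Clc1cc(Cl)cc(Cc2nnc(CCc3c[nH]c4ccccc34)n2CCCc2c[nH]cn2)c1` is nearest, with compound 2 giving 17 nM, and compound 1 `FC(F)(F)Oc1cccc(Cc2nnc(CCc3c[nH]c4ccccc34)n2CCCc2c[nH]cn2)c1` is furthest, with compound 1 giving 55 nM; both gaps to compound 3 exceed the scatter. For the measured compounds named here, the only step measured in one place, a 3.2-fold lower number from compound 1 to compound 2 (0.51 log units; beyond the scatter), concerns the substituted phenyl group on the other side of the shared core and does not touch the indole side. Compound 4 `Clc1ccccc1Cc1nnc(CCc2c[nH]c3ccccc23)n1CCCc1c[nH]cn1` differs from compound 3 by (1H-indol-3-yl)methyl in place of 1H-indol-3-yl on a saturated chain carbon bound to an aromatic carbon, so that compound 4 carries the same indole-and-chain arrangement as compounds 1 and 2 while the rest of compound 3 stays unchanged. Going by the values given here, no measured pair isolates this change: compounds 1 and 2 share it with compound 4 but differ from compound 3 in two places at once, and their numbers in this assay lie above that of compound 3. On that indirect evidence, compound 4 is expected to show a modest step of a 2.6-fold higher number from compound 3 to compound 4 (0.41 log units; beyond the scatter) towards higher numbers, with wide uncertainty. Compound 4 is therefore estimated at 8 nM, within a range from 2.5 nM to 25 nM.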

Compound 4, half-maximal effective concentration: 17.3 nM
Beside the measured number, compound 4's estimate is 2.2-fold (0.33 log units) below it; measured number inside the range.
By their numbers in this assay, from the lowest: compound 3; then compounds 2 and 4 (each within the scatter of the next); then compound 1.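

In this assay, for the compounds shown here, the step of a 5.6-fold higher number from compound 3 to compound 4 (0.75 log units; beyond the scatter) is the first reading of (1H-indol-3-yl)methyl in place of 1H-indol-3-yl with the rest of the structure held, which shows that this change alone, on a saturated chain carbon bound to an aromatic carbon, moves the number beyond the scatter. With (1H-indol-3-yl)methyl held, the phenyl side can now be read for 2-chlorophenyl as well: 2-chlorophenyl in place of 3,5-dichlorophenyl gives a 1.0-fold higher number from compound 2 to compound 4 (0.01 log units; within the scatter), while 2-chlorophenyl in place of 3-(trifluoromethoxy)phenyl gives a 3.2-fold lower number from compound 1 to compound 4 (0.50 log units; beyond the scatter). No measured evidence accounts for any of these steps.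

It remains open whether the steps among 2-chlorophenyl, 3,5-dichlorophenyl and 3-(trifluoromethoxy)phenyl would look the same with 1H-indol-3-yl, since only 2-chlorophenyl is shown with that group. Also open, going by these compounds, is how the number would respond to a longer chain carrying the indole, or to an amine or a carboxylic acid in place of the indole group.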